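The compounds below may be only part of what the source reports. "The series", "measured", "known", "first", "only" and "open" are said of these compounds alone.

Measured so far:
- compound 1 `COc1cc(OCc2cccc(COc3ccccc3)c2)c2cc(-c3cn4nc(OC)sc4n3)oc2c1` — in a functional assay on HEK293 cells for antagonist activity at proteinase-activated receptor 4 (Homo sapiens), read by FLIPR and calcium flux, with a stated time of 30 min (a lower number here means a stronger inhibitor, a higher number a weaker inhibitor), compound 1 gives 3.2 nM
- compound 2 `COc1cc(OCc2cccc(Sc3ccccc3)c2)c2cc(-c3cn4nc(OC)sc4n3)oc2c1` — compound 2 gives 0.89 nM
- compound 3 `COc1cc(OCc2cccc(C#N)c2)c2cc(-c3cn4nc(OC)sc4n3)oc2c1` — compound 3 gives 0.98 nM

Compound 3 sits second of the three numbers; it is within the scatter of compound 2 and well apart from compound 1, as the step of a 3.3-fold lower number from compound 1 to compound 3 (0.51 log units; beyond the scatter) shows. The next compound, compound 4 `COc1cc(OCc2cccc(Oc3ccccc3)c2)c2cc(-c3cn4nc(OC)sc4n3)oc2c1`, is not yet measured. It differs from compound 3 by phenoxy in place of cyano on an aromatic carbon.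

Going by the values given here, no measured step swaps cyano for phenoxy directly. The nearest guides are the two steps that leave phenoxymethyl: a 3.6-fold lower number from compound 1 to compound 2 (0.56 log units; beyond the scatter) and a 3.3-fold lower number from compound 1 to compound 3 (0.51 log units; beyond the scatter), while a 1.1-fold higher number from compound 2 to compound 3 (0.04 log units; within the scatter) is within the scatter. Phenoxy shares the oxygen-linked phenyl of phenoxymethyl but, like phenylsulfanyl, has no methylene; the expectation is therefore a number between those of compound 1 and compound 2, that is a small upward step from compound 3, a 1.6-fold higher number from compound 3 to compound 4 (0.21 log units; within the scatter), possibly within the scatter. Compound 4 is expected to give about 1.6 nM in this assay, with a range from 0.5 nM to 5 nM.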

Compound 4, half-maximal inhibitory concentration: 1.2 nM
For compound 4 the middle estimate is 1.3-fold (0.12 log units) above the measured one, within the range that was stated.
By their numbers in this assay, from the lowest: compounds 2, 3 and 4 (each within the scatter of the next); then compound 1.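

In this assay, phenoxy at this aromatic carbon cannot be told apart from cyano (a 1.2-fold higher number from compound 3 to compound 4 (0.09 log units; within the scatter)) or from phenylsulfanyl (a 1.3-fold higher number from compound 2 to compound 4 (0.13 log units; within the scatter)), so an entering group of 7 heavy atoms with an aromatic ring reads the same as a leaving group of 2 heavy atoms with no ring. Phenoxymethyl alone stands apart among the four compounds (a 2.7-fold lower number from compound 1 to compound 4 (0.43 log units; beyond the scatter)), and that step takes away only a methylene. No data on the cause of this separation are available.

From the compounds shown here alone, it remains open whether an amine, a carboxylic acid or a longer chain such as phenethoxy at this aromatic carbon would stay with compound 2, compound 3 and compound 4 or move toward compound 1. Going by these compounds, all four compounds share one core, so whether the same reading holds on any other core is also open.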